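The source may hold more compounds than are shown below. What is called first, only, known or untested is meant among the compounds shown, and "the series" means these compounds.

Values in an ADME assay on HUVEC cells (Homo sapiens) for inhibition, read by CCK-8 assay, with a stated time of 24 h, in the presence of a further agent that is not named here; a lower number here means a stronger inhibitor, a higher number a weaker inhibitor

Compound 1 (`O=C1Nc2ccccc2/C1=C/c1ccc(-c2cn(-c3cccc(F)c3)nn2)cc1`) , a limit: > 20000 nM
Compound 2 (`N#Cc1cccc(-n2cc(-c3ccc(/C=C4\C(=O)Nc5ccccc54)cc3)nn2)c1`) , a limit: > 20000 nM
Compound 3 (`Cc1ccc(-n2cc(-c3ccc(/C=C4\C(=O)Nc5ccc(F)cc54)cc3)nn2)cc1`) : 13800 nM

In this assay, within the data shown here, compound 3 is the only compound with a number, at 13800 nM. The other two values are limits. The data so far are thin, with the limit of > 20000 nM in this assay, at which 2 of the 3 values shown sit, as the main feature. Among the measured compounds shown here, the only measured step, a step that the two limits leave unreadable from compound 1 to compound 2, has no readable size and so gives no size to carry over.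

The next change leads to compound 4 (`O=C1Nc2ccc(F)cc2/C1=C/c1ccc(-c2cn(-c3cccc(Cl)c3)nn2)cc1`) and is 3-chlorophenyl in place of 4-methylphenyl on an aromatic nitrogen, with 3-chlorophenyl in place of 4-methylphenyl on an aromatic nitrogen. For the measured compounds named here, no measured step covers this swap. The expectation therefore rests on compound 3 at 13800 nM, with no clear shift beyond the scatter anticipated. The expected outcome is a 1.2-fold higher number from compound 3 to compound 4 (0.06 log units; within the scatter), and a reading at the limit of the assay could also occur. Compound 4 is estimated at 16000 nM, with an expected range of 8000 nM to 30000 nM.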

Compound 4, half-maximal inhibitory concentration: 19400 nM
Compound 4: the middle estimate sits 1.2-fold (0.08 log units) below what was measured; low and high end bracket the measured number.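

In this assay, among these compounds, the exchange of 4-methylphenyl for 3-chlorophenyl on the aromatic nitrogen gives the first readable step: a 1.4-fold higher number from compound 3 to compound 4 (0.15 log units; within the scatter). Among the compounds shown here, on the core of compound 3, this position therefore accepts a change in both the substituent and its place on the phenyl ring with no shift beyond the scatter, whereas the only earlier step, between compound 1 and compound 2, could not be read. Room to read further steps remains narrow: the limit of > 20000 nM in this assay, at which 2 of the 4 values shown sit.

Still open, from the compounds shown here alone, is whether a different kind of group on the phenyl ring at this position, such as an amine or a carboxylic acid, would move the number clear of the limit. Also open is the contribution of the fluoro on the core, which no pair shown isolates.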